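The source may hold more compounds than are shown below. What is called first, only, known or untested is meant among the compounds shown, and "the series" means these compounds.

Of the compounds shown here, two of a shared core have been measured in an assay on HEK293 cells for displacement of a labelled ligand from 5-hydroxytryptamine receptor 6 (Homo sapiens), read by scintillation counting, with a stated time of 1 h; on this read-out lower numbers stand for stronger inhibition and higher numbers for weaker inhibition. Compound 1 `Cc1[nH]c2ccc(OS(=O)(=O)C(F)(F)F)cc2c1C1=CCNCC1` gives 50 nM in this assay. Compound 2 `Cc1c(C2=CCNCC2)c2cc(Cl)ccc2n1C` gives 40 nM in this assay, the lower of the two numbers, though its gap to compound 1 lies within the scatter, so the two cannot be ranked. Compound 3 `CCCn1c(C)c(C2=CCNCC2)c2cc(Cl)ccc21` differs from compound 2 by ethyl in place of hydrogen on a saturated chain carbon bound to an aromatic nitrogen. Among the compounds with values here, no measured pair shows this change, so nothing more than a modest step, if any, is expected; a slight weakening is thought most likely. Compound 3 is therefore estimated at 70 nM, in the range 20 nM to 250 nM, which would mean an expected step of a 1.8-fold higher number from compound 2 to compound 3 (0.24 log units; within the scatter).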

Compound 3, half-maximal inhibitory concentration: 80 nM
The estimate for compound 3 lay 1.1-fold (0.06 log units) below the measured number; the measured number falls inside the stated range.
By their numbers in this assay, from the lowest: compounds 2, 1 and 3 (each within the scatter of the next).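

In this assay, ethyl in place of hydrogen on a saturated chain carbon bound to an aromatic nitrogen, which also reads as methyl to propyl, gives a 2.0-fold higher number from compound 2 to compound 3 (0.30 log units; within the scatter). This first step at this place shows that the added ethyl leaves the number within the scatter, so compound 2 and compound 3 cannot be ranked. Nothing available here accounts for the step. Open, on these data alone, is whether a longer chain, such as butyl, or a chain ending in an amine or a carboxylic acid would stay within the scatter as well.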